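Carbonyl substituent change from compound 3 to compound 4

A few compounds are considered here, and "the series" means these few. Any claim that something is new, unique, unknown or untested is made for them only; others in the source may bear on it.

Values in a functional assay on MCF7 cells (Homo sapiens) for antiproliferative activity, read by MTT assay, with a stated time of 48 h; on this read-out lower numbers stand for stronger inhibition and higher numbers for weaker inhibition:
compound 1 `CCn1c(C(=O)NCCN(C)C)ccc1C(CC)(CC)c1ccc(OCCC(O)(CC)CC)c(C)c1`: 430 nM
compound 2 `C=CCN(C)C(=O)c1ccc(C(CC)(CC)c2ccc(OCCC(O)(CC)CC)c(C)c2)n1CC`: > 50000 nM (a limit)
compound 3 `C#CCCOC(=O)c1ccc(C(CC)(CC)c2ccc(OCCC(O)(CC)CC)c(C)c2)n1CC`: > 50000 nM (a limit)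

Compound 3 has no number, only a limit, and stands at the limit of > 50000 nM in this assay, at which 2 of the 3 values shown sit. Compound 4 `CCC(C)C(NC(=O)c1ccc(C(CC)(CC)c2ccc(OCCC(O)(CC)CC)c(C)c2)n1CC)C(=O)O` carries (1-carboxy-2-methylbutyl)amino in place of (but-3-yn-1-yl)oxy on a carbonyl carbon.

The bearing steps are an at least 110-fold higher number from compound 1 to compound 2 (2.06 log units; beyond the scatter) and an at least 110-fold higher number from compound 1 to compound 3 (2.06 log units; beyond the scatter), both large. The step that the two limits leave unreadable from compound 2 to compound 3 gives no size. Compound 4 lacks the (2-(dimethylamino)ethyl)amino of compound 1, so only a modest move towards a lower number is expected in this assay, and a result at the limit remains likely.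

The expected change is an at least 2.0-fold lower number from compound 3 to compound 4 (0.30 log units; that floor lies within the scatter). The estimate for compound 4 is 25000 nM, with an expected range of 3000 nM to 50000 nM.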

Compound 4, half-maximal inhibitory concentration: 11300 nM
The estimate for compound 4 lay 2.2-fold (0.34 log units) above the measured number, within the range that was stated.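

On the carbonyl carbon, a group other than the (2-(dimethylamino)ethyl)amino of compound 1 can still give a number in this assay, and compound 4 moves off the limit that holds for compound 2 and compound 3: the limit of > 50000 nM in this assay, at which 2 of the 4 values shown sit.

The (1-carboxy-2-methylbutyl)amino group gives an at least 4.4-fold lower number from compound 3 to compound 4 (0.64 log units; beyond the scatter) and an at least 4.4-fold lower number from compound 2 to compound 4 (0.64 log units; beyond the scatter). It does not match the group in compound 1, with a 26-fold higher number from compound 1 to compound 4 (1.42 log units; beyond the scatter).

Still open, from the compounds shown here alone, is whether the shift follows the carboxylic acid or the amide hydrogen. Also open, going by these compounds, is whether a primary amine on a longer chain would recover the value of compound 1.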